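Disulfide thymidine series: half-life

The source may hold more compounds than are shown below. What is called first, only, known or untested is meant among the compounds shown, and "the series" means these compounds.

Measured compounds:
compound 1, `Cc1cn([C@H]2C[C@H](SSc3ccccc3[N+](=O)[O-])[C@@H](CO)O2)c(=O)[nH]c1=O`, gives < 0.0834 h (a limit)
compound 2, `CCCCCCCCSS[C@H]1C[C@H](n2cc(C)c(=O)[nH]c2=O)O[C@@H]1CO`, gives < 0.0834 h (a limit)

In a physicochemical assay for pharmacokinetics, at pH 7.2 (a lower number here means that the compound disappears faster, a higher number that the compound lasts longer), compound 1 reaches only the limit of the assay, < 0.0834 h. Compound 2 likewise sits at the limit, < 0.0834 h. The step that the two limits leave unreadable from compound 1 to compound 2 cannot be sized because of the limit of < 0.0834 h in this assay, at which 2 of the 2 values shown sit. Compound 3, `Cc1cn([C@H]2C[C@H](SSCCCCCCO)[C@@H](CO)O2)c(=O)[nH]c1=O`, differs from compound 2 by hydroxy in place of ethyl on a saturated chain carbon, six bonds along the chain from a sulfur. Among the compounds with values here, no measured step covers this change, and compound 2 itself stands only at a limit in this assay. The step is estimated as a step that the limit leaves unreadable from compound 2 to compound 3, meaning no readable change. Compound 3 is expected at 0.05 h, between 0.02 h and 0.15 h, most probably again reported as a limit.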

Compound 3, half-life: < 0.0834 h
Compound 3: a limit, no number (the forecaster's own chance of this, stated with the estimate: 75%); the middle value does not contradict the limit.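

In this assay compound 3 gives < 0.0834 h as a limit. Within the data shown here, no step among compound 1, compound 2 and compound 3 can be read. Still open is how the half-lives of these compounds compare, and whether the group on the sulfur changes them at all.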